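A few compounds are considered here, and "the series" means these few. Any claim that something is new, unique, unknown or untested is made for them only; others in the source may bear on it.

In a functional assay on MCF7 cells (Homo sapiens) for inhibition, read by colorimetric assay and MTT assay, with a stated time of 72 h (on this read-out higher numbers stand for weaker inhibition and lower numbers for stronger inhibition), compound 1 (`C=CCCCCOc1ccccc1-c1cnc(OCCC=C)n1C`) gives 8000 nM, compound 2 (`C=CCCCCOc1ccccc1-c1cnc(OCCCC=C)n1C`) gives 7000 nM and compound 3 (`C=CCCCCOc1ccccc1-c1cnc(OCCCCC=C)n1C`) gives 5000 nM, which places compound 3 within the scatter of both. Compound 4 (`C=CCCCCOc1ncc(-c2ccccc2OC)n1C`) differs from compound 3 by hydrogen in place of pent-4-en-1-yl on a saturated chain carbon bound to an oxygen on an aromatic ring, a change that also reads as hex-5-en-1-yl to methyl. The measured steps bear on this only indirectly. The steps of a 1.1-fold lower number from compound 1 to compound 2 (0.06 log units; within the scatter), a 1.6-fold lower number from compound 1 to compound 3 (0.20 log units; within the scatter) and a 1.4-fold lower number from compound 2 to compound 3 (0.15 log units; within the scatter) all lie within the scatter, but they alter a different chain and leave this hex-5-en-1-yl untouched. A modest rise in this assay is therefore expected, an estimated 2.4-fold higher number from compound 3 to compound 4 (0.38 log units; beyond the scatter), with wide uncertainty. Compound 4 is estimated at 12000 nM, with an expected range of 4500 nM to 35000 nM.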

Compound 4, half-maximal inhibitory concentration: 5000 nM
Beside the measured number, compound 4's estimate is 2.4-fold (0.38 log units) above it; low and high end bracket the measured number.
By their numbers in this assay, from the lowest: compounds 3, 4, 2 and 1 (each within the scatter of the next).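

Replacing the hex-5-en-1-yl chain with methyl, so that (hex-5-en-1-yl)oxy becomes methoxy, gives no change at the digits printed from compound 3 to compound 4 (within the scatter) in this assay on the shared core. The earlier compounds shown here altered only the other chain, whereas this step shows that at this position the pent-4-en-1-yl portion, with its double bond outside aromatic rings, can be lost without a change beyond the scatter. Nothing available explains this result. Going by these compounds, whether an amine, a carboxylic acid or a chain longer than hex-5-en-1-yl at this position would keep the number there remains open.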